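Carbamoylpiperidine in place of pyrrolidine: expected binding shift

The source may hold more compounds than are shown below. What is called first, only, known or untested is meant among the compounds shown, and "the series" means these compounds.

compound 2 `O=S(=O)(c1ccccc1)c1cnc2ccccc2c1N1CCCC1` — 7.1%
compound 1 `CCOC(=O)C1CCN(c2c(S(=O)(=O)c3ccccc3)cnc3ccccc23)CC1` — 33%

For the measured compounds named here, in an assay on isolated protein for displacement of a labelled ligand from metabotropic glutamate receptor 5 (Homo sapiens), with a stated time of 60 min, tested at 1 uM (on this read-out lower numbers stand for less inhibition and higher numbers for more inhibition at the one concentration tested (going by the name of the read-out)), compound 2 gives 7.1%, the lowest of the two numbers measured so far. Compound 1 gives 33%, higher than compound 2 by more than the usual scatter. Compound 3 `NC(=O)C1CCN(c2c(S(=O)(=O)c3ccccc3)cnc3ccccc23)CC1` has not yet been measured; it differs from compound 2 by 4-carbamoylpiperidin-1-yl in place of pyrrolidin-1-yl on an aromatic carbon. Going by the values given here, no measured pair shows this exact change, so the step is estimated from compound 1 alone. Compound 3 is expected to rise beyond the scatter by a number 19.9 percentage points higher from compound 2 to compound 3 (beyond the scatter), because compound 1, which carries a six-membered ring at the same place, gives 33%. Compound 3 is expected near 27%, within a range of 8% to 50%.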

Compound 3, a percentage reported as inhibition, at one concentration (the size of the read-out at that concentration, not a potency): 24.8%
The estimate for compound 3 lay 2.2 percentage points above the measured number, within the range that was stated.
By their numbers in this assay, from the lowest: compound 2; then compounds 3 and 1 (each within the scatter of the next).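

In this assay, 4-carbamoylpiperidin-1-yl in place of pyrrolidin-1-yl on this aromatic carbon gives a number 17.7 percentage points higher from compound 2 to compound 3 (beyond the scatter), so the rise at this place does not depend on the ethyl ester of compound 1. Amino in place of ethoxy on a carbonyl carbon gives a number 8.2 percentage points lower from compound 1 to compound 3 (within the scatter), which leaves the amide and the ester not told apart here. Nothing measured on these compounds accounts for either step.

Open, on these data alone, is how much of the rise belongs to the six-membered ring and how much to its carbonyl substituent, which unsubstituted piperidin-1-yl would separate. Also open, as far as these compounds go, is how a carboxylic acid or an aminomethyl group would read in place of the amide.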